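This account rests on a few compounds, and the source may have more. Where it says the series, first, only, none or still open, it means among the compounds named here.

Measured compounds:
compound 1 `COc1cccc(CNCc2c(C(=O)O)n(Cc3ccccc3)c3cc(C(C)C)ccc23)c1`, 3180 nM
compound 2 `COc1ccc(Cn2c(C(=O)O)c(CN(C)Cc3cccc(OC)c3)c3ccc(C)cc32)cc1`, 15400 nM
compound 3 `COc1ccc(Cn2c(C(=O)O)c(CNCc3ccc(O)c(OC)c3)c3ccc(C)cc32)cc1`, 3740 nM

In a functional assay on HepG2 cells (Homo sapiens) for antiproliferative activity, read by MTT assay, with a stated time of 72 h (on this read-out lower numbers stand for stronger inhibition and higher numbers for weaker inhibition), compound 1 gives the lowest of the three numbers; compound 3 lies within the scatter of it, while compound 2 stands beyond the scatter above both. For the measured compounds named here, the only step within the measured set is a 4.1-fold lower number from compound 2 to compound 3 (0.61 log units; beyond the scatter), which alters the amine part of the side chain and leaves the benzyl group on the core untouched. Compound 4 `COc1cccc(CNCc2c(C(=O)O)n(Cc3ccccc3F)c3cc(C(C)C)ccc23)c1` differs from compound 1 by fluoro in place of hydrogen on an aromatic carbon. No measured pair varies the benzyl group, so nothing shown bears directly on this change; by default a step within the scatter is expected, a 1.1-fold lower number from compound 1 to compound 4 (0.03 log units; within the scatter). Compound 4 is therefore estimated at 3000 nM in this assay, with a range of 1200 nM to 7500 nM.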

Compound 4, half-maximal inhibitory concentration: 3300 nM
For compound 4 the middle estimate is 1.1-fold (0.04 log units) below the measured one; the range from low to high includes it.
By their numbers in this assay, from the lowest: compounds 1, 4 and 3 (each within the scatter of the next); then compound 2.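

In this assay, for the compounds shown here, 2-fluorobenzyl in place of benzyl gives a 1.0-fold higher number from compound 1 to compound 4 (0.02 log units; within the scatter) and is the first measured change to this group. Fluoro on this aromatic carbon, ortho to a large group, therefore leaves the number within the scatter in this pair, so this position accepts this one small substitution without a readable shift. Nothing available accounts for this result.

As far as these compounds go, whether a larger group such as chloro, methoxy or trifluoromethyl behaves alike at this carbon remains open. From the compounds shown here alone, the effect of fluoro on the other carbons of this ring, and on the cores of compound 2 and compound 3, also remains open.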